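The source may hold more compounds than are shown below. What is called first, only, known or untested is meant among the compounds shown, and "the series" means these compounds.

Measured compounds:
compound 1, `CC1(C)CC(NC(=O)NCc2ccccc2)c2cc(Cl)ccc2O1`, 15000 nM
compound 2, `CC1(C)CC(NC(=O)NCc2ccccc2)c2cc(F)ccc2O1`, 49000 nM

In a functional assay on T98G cells (Homo sapiens) for inhibition, read by MTT assay, with a stated time of 72 h (a higher number here means a weaker inhibitor, a lower number a stronger inhibitor), compound 1 gives the lowest of the two numbers; the nearest is compound 2, and the step of a 3.3-fold higher number from compound 1 to compound 2 (0.51 log units; beyond the scatter). Compound 3, `CC1(C)CC(NC(=O)Nc2ccccc2Cl)c2cc(Cl)ccc2O1`, carries a different change: 2-chlorophenyl in place of benzyl on an amide-type nitrogen. Among the measured compounds shown here, no measured step touches this amide-type nitrogen, so the data give no direction for it. The expected step is therefore no change at the digits printed from compound 1 to compound 3 (within the scatter), set at no change and carrying a wide range. Compound 3 is estimated to give 15000 nM in this assay, between 4000 nM and 60000 nM.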

Compound 3, half-maximal inhibitory concentration: 20000 nM
Estimate against measurement, compound 3: 1.3-fold (0.12 log units) below; the range from low to high includes it.
By their numbers in this assay, from the lowest: compounds 1 and 3 (each within the scatter of the next); then compound 2.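

Among the compounds shown here, at the amide-type nitrogen, where no earlier pair gave any reading, this assay shows no change beyond the scatter when 2-chlorophenyl replaces benzyl, with a 1.3-fold higher number from compound 1 to compound 3 (0.12 log units; within the scatter) as the step. This nitrogen therefore accepts this one swap without a measurable shift, though one pair sets no general rule. Nothing measured here offers a reason for this result. The compounds shown leave open what an unsubstituted phenyl or a longer chain such as 2-phenylethyl would do on this nitrogen. They also leave open whether 2-chlorophenyl would behave alike with fluoro in place of chloro on the core.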